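The source may report more compounds than this note shows. Statements on the series, on what has been measured and on what is new or still open speak of the compounds shown alone.

The measured compounds and their values:

Compound 1 `ClCc1cccc(Cn2cnc3c(Cl)ncnc32)c1` gives 1620 nM.
Compound 2 `ClCc1cccc(Cn2cnc3c(Cl)nc(Cl)nc32)c1` gives 1580 nM.
Compound 3 `ClCc1ccccc1Cn1cnc2ncnc(Cl)c21` gives 2040 nM.

All three were tested in a functional assay on OVCAR-3 cells (Homo sapiens) for cytotoxicity, read by sulforhodamine B assay, with a stated time of 48 h; a higher number here means a weaker inhibitor of growth, a lower number a stronger inhibitor of growth. Compound 1 and compound 2 share a core and differ in one place only: chloro in place of hydrogen on an aromatic carbon. This change made the step of a 1.0-fold lower number from compound 1 to compound 2 (0.01 log units; within the scatter), so the two values cannot be told apart by this measurement.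

Compound 3 is built from the same atoms as compound 1, joined differently; the difference between the two cores is not broken down here. Its value and that of compound 1 lie within the scatter of each other, as do its value and that of compound 2, so nothing can be said about an order among the three.

Compound 4 `ClCc1ccccc1Cn1cnc2nc(Cl)nc(Cl)c21` has not yet been measured. It differs from compound 3 in one place: chloro in place of hydrogen on an aromatic carbon. Within the data shown here, this is the same change as the one from compound 1 to compound 2, made on the core of compound 3 instead. Because a 1.0-fold lower number from compound 1 to compound 2 (0.01 log units; within the scatter) was within the scatter, the expected step of a 1.0-fold lower number from compound 3 to compound 4 (0.01 log units; within the scatter) is also small. On that basis, compound 4 is expected to give about 2000 nM in this assay, with an estimated range from 1000 nM to 4000 nM. That expectation rests on a single measured pair, so it is a loose one.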

Compound 4, concentration for 50% growth inhibition: 14100 nM
Compound 4: middle estimate off by 7.1-fold (0.85 log units), on the low side; the whole stated range lies below it.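

In this assay, putting chloro in place of hydrogen on an aromatic carbon, at the ring carbon between two ring nitrogen atoms, gave a 6.9-fold higher number from compound 3 to compound 4 (0.84 log units; beyond the scatter), so on this core the change weakened growth inhibition. The same change therefore cannot be assumed to do the same thing on both cores of this series, as the two steps set side by side show: the same change on two cores in this assay, a 1.0-fold lower number (0.01 log units; within the scatter) from compound 1 to compound 2 and a 6.9-fold higher number (0.84 log units; beyond the scatter) from compound 3 to compound 4, 7.1-fold (0.85 log units) apart, beyond the scatter of two such steps. This shows that the outcome of the change depended on the core it was made on, but it does not show which feature of the two cores is responsible or why the outcome differs, and two pairs give no rule for any further core.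

From the compounds shown here alone, it remains open whether the sharp difference is particular to chloro, or whether an amine or a methoxy group at the same ring carbon would also be tolerated on the core of compound 1 and not on the core of compound 3. Going by these compounds, it also remains open whether the chloromethyl group matters for this difference, which a hydroxymethyl group in its place on both cores could help to test.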